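A few compounds are considered here, and "the series" means these few. Any claim that something is new, unique, unknown or untested is made for them only; others in the source may bear on it.

Measured so far:
compound 1 `CCOC(=O)CNC(=O)NC1=CS(=O)(=O)O[C@@]12[C@@H](CO[Si](C)(C)C(C)(C)C)O[C@@H](n1cc(C)c(=O)n(C)c1=O)[C@@H]2O[Si](C)(C)C(C)(C)C`; in a functional assay on HEL cells (Homo sapiens) (a higher number here means that more compound is tolerated, a lower number that less compound is tolerated), compound 1 gives 13000 nM.
compound 2 `Cc1cn([C@@H]2O[C@@H]3COC(=O)[C@]3(OS(C)(=O)=O)[C@H]2O)c(=O)[nH]c1=O`; for compound 2 this assay reports only a limit, >= 36000 nM.

Going by the values given here, compound 1 stands as the holder of the only actual number in this assay; the other value shown is a limit, as the limit of >= 36000 nM in this assay, at which 1 of the 2 values shown sits, records. Among the compounds with values here, no pair of measured compounds differs in a single place, so no measured step is available to anchor the series.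

Compound 3 `Cc1cn([C@@H]2O[C@H](CO[Si](C)(C)C(C)(C)C)[C@@]3(OS(=O)(=O)C=C3NCC(=O)O)[C@H]2O[Si](C)(C)C(C)(C)C)c(=O)n(C)c1=O` differs from compound 1 in one place: carboxymethyl in place of ((ethoxycarbonyl)methyl)carbamoyl on an amine nitrogen. Within the data shown here, with no measured step to draw on, the change is expected to move the half-maximal cytotoxic concentration only a little, if at all, and in the direction of more compound tolerated, so the expected step is a 1.5-fold higher number from compound 1 to compound 3 (0.19 log units; within the scatter), which may not stand out from the scatter. Compound 3 is accordingly estimated at 20000 nM, with a range from 7000 nM to 60000 nM, and a fair chance that this assay returns only a limit for it.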

Compound 3, half-maximal cytotoxic concentration: 136000 nM
Estimate against measurement, compound 3: 6.8-fold (0.83 log units) below; measured number above the stated range.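

Going by these compounds alone, on an amine nitrogen, the substituent matters in this assay: carboxymethyl in place of ((ethoxycarbonyl)methyl)carbamoyl gives a 10-fold higher number from compound 1 to compound 3 (1.02 log units; beyond the scatter) and is the first measured step. This step lies beyond the scatter, so a change at this one position, with the rest of the core of compound 1 unchanged, can shift how much compound is tolerated. Nothing shown accounts for the size of this step.

Since the whole group changes at once, the compounds shown leave open whether the loss of the carbamoyl or the change at the chain end carries the step. The same question remains for (ethoxycarbonyl)methyl set directly on the amine nitrogen, and for a longer chain ending in a carboxylic acid.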